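Para-substituent swap on the thione core of compound 3

The compounds below may be only part of what the source reports. "The series", "measured", "known", "first", "only" and "open" are said of these compounds alone.

Compound 1 `CCC(C)Sc1nc2c(cc(-c3ccc(Cl)cc3)n2-c2ccccc2)c(=N)s1` and compound 2 `CCC(C)Sc1nc2c(cc(-c3ccc(C)cc3)n2-c2ccccc2)c(=N)s1` share one core; compound 3 `CCn1c(=S)[nH]c2c(cc(-c3ccc(Cl)cc3)n2-c2ccccc2)c1=N` and the unmeasured compound 4 `CCn1c(=S)[nH]c2c(cc(-c3ccc(C)cc3)n2-c2ccccc2)c1=N` share another. The difference between the two cores is not broken down here. In a functional assay on the whole organism for inhibition, with Rattus norvegicus as the target, read by ELISA, with stated times of 30 min and 6 h, at a dose of 30 mg/kg by the oral route (on this read-out lower numbers stand for less inhibition and higher numbers for more inhibition at the one dose given (going by the name of the read-out)), compound 1 gives 2%. In this assay compound 2 gives 2%. The change between them is methyl in place of chloro on an aromatic carbon, and it produced no change at the digits printed from compound 1 to compound 2 (within the scatter). In this assay compound 3 gives 61%, which is beyond the scatter above compound 1 and compound 2. Compound 4 arises from compound 3 by methyl in place of chloro on an aromatic carbon, the same change as from compound 1 to compound 2, at the same place. The expectation is that the step of a number 6 percentage points lower from compound 3 to compound 4 (within the scatter) stays within the scatter, because in this assay the same change gave no change at the digits printed from compound 1 to compound 2 (within the scatter), though the earlier pair sits near the floor of the read-out and the core of compound 3 is different. In this assay compound 4 is estimated at 55%, with a range from 35% to 72%.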

Compound 4, a percentage reported as inhibition, in the whole organism at one dose (the size of the read-out at that dose, not a potency): 60%
Compound 4: the middle estimate sits 5 percentage points below what was measured; measured number inside the range.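

In this assay the change from 4-chlorophenyl to 4-methylphenyl on the core of compound 3 reads as a number 1 percentage points lower from compound 3 to compound 4 (within the scatter), so on this core the swap leaves the read-out without a change that can be told apart from scatter. Set beside the earlier pair, the swap carries from one core to the other without a difference between the two steps: the same change on two cores in this assay, no change at the digits printed (within the scatter) from compound 1 to compound 2 and a number 1 percentage points lower (within the scatter) from compound 3 to compound 4, 1 percentage points apart, within the scatter of two such steps This rests on two pairs, one of them near the floor of the read-out, and covers a single swap at a single place at one dose, so it does not show that other changes would carry between these cores, and it says nothing about what separates the cores themselves.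

Only chloro and methyl appear at this place, which leaves open what an amine or a carboxylic acid would do there. Also open, from the compounds shown here alone, is which part of the difference between the cores carries the gap in the read-out, and what a longer chain in place of the ethyl on the core of compound 3 would give.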